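From compound 1 to compound 4: one group exchanged

The compounds below may be only part of what the source reports. "The series", "measured", "known", "first", "only" and "open" are said of these compounds alone.

In a toxicity assay on L02 cells (Homo sapiens) for cytotoxicity, read by MTT assay, with a stated time of 72 h (on this read-out higher numbers stand for weaker inhibition and lower numbers for stronger inhibition), compound 1 `O=C1c2c[n+]([O-])c3ccccc3c2C(=O)c2c1c1ccccc1n2Cc1cn([C@@H]2C[C@H](O)[C@@H](CO)O2)nn1` gives 630 nM. Compound 3 `O=C1c2c[n+]([O-])c3ccccc3c2C(=O)c2c1c1ccccc1n2CCN1CCCC1` gives 930 nM, within the scatter of compound 1. Compound 2 `CN1CCN(CCCCn2c3c(c4ccccc42)C(=O)c2c[n+]([O-])c4ccccc4c2C3=O)CC1` gives 80 nM, a lower number than the other two and beyond the scatter of both.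

Compound 4 `CC1(C)OC[C@@H](Cn2cc(Cn3c4c(c5ccccc53)C(=O)c3c[n+]([O-])c5ccccc5c3C4=O)nn2)O1` keeps the core of compound 1 and exchanges one group on an aromatic nitrogen of a five-membered aromatic ring with 3 nitrogen: (2,2-dimethyl-1,3-dioxolan-4-yl)methyl in place of 4-hydroxy-5-(hydroxymethyl)oxolan-2-yl on an aromatic nitrogen. In words, (2,2-dimethyl-1,3-dioxolan-4-yl)methyl comes in place of 4-hydroxy-5-(hydroxymethyl)oxolan-2-yl.

For the measured compounds named here, only one measured step bears on this, and only indirectly: a 12-fold higher number from compound 2 to compound 3 (1.07 log units; beyond the scatter). That large step shows how far this assay can move with a change of side group. However, it concerns pyrrolidin-1-yl in place of 2-(4-methylpiperazin-1-yl)ethyl, at another place on another side chain. Going by the values given here, no measured pair changes the group exchanged here, so the data give no direction for this change.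

No shift beyond the scatter is therefore expected, though the range is kept wide. In this assay the expected change is a 1.1-fold lower number from compound 1 to compound 4 (0.02 log units; within the scatter), an estimate within the scatter. For compound 4 the estimated value is 600 nM, expected to fall between 200 nM and 1800 nM.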

Compound 4, half-maximal inhibitory concentration: 2900 nM
Beside the measured number, compound 4's estimate is 4.8-fold (0.68 log units) below it; measured number outside the range, above it.
By their numbers in this assay, from the lowest: compound 2; then compounds 1 and 3 (each within the scatter of the next); then compound 4.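

In this assay, for the compounds shown here, the group on an aromatic nitrogen of a five-membered aromatic ring with 3 nitrogen does affect the read-out: (2,2-dimethyl-1,3-dioxolan-4-yl)methyl in place of 4-hydroxy-5-(hydroxymethyl)oxolan-2-yl gives a 4.6-fold higher number from compound 1 to compound 4 (0.66 log units; beyond the scatter), the only measured step at this position. Both groups have 8 heavy atoms, so that count does not separate them, while hydrogen-bond donors go from 2 to 0, hydrogen-bond acceptors from 3 to 2 and defined stereocentres from 3 to 1, and the ring changes from 1 hetero atom to 2. These differences all change in this single exchange, and no measurement here connects the step with any one of them.

Open, as far as these compounds go, is whether the step follows the hydrogen-bond donor count or the change of ring: a 2,3-dihydroxypropyl group at the same place would help separate the two. Also open, from the compounds shown here alone, is how this assay responds on this aromatic nitrogen to an amine such as 4-methylpiperazin-1-yl, to a carboxylic acid or to a longer chain carrying either group.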